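The source may hold more compounds than are shown below. What is called first, only, known or untested is meant among the compounds shown, and "the series" means these compounds.

Measured in a physicochemical assay for solubility, read by HPLC, in phosphate buffer, measured as kinetic solubility, with a stated time of 1 h, at pH 7.4, tested at 250 uM; on this read-out lower numbers stand for lower solubility and higher numbers for higher solubility:
- Compound 1 `O=C(NCCCCc1ccccc1)n1cc(-c2ccccc2)oc1=O`: < 1000 nM, a limit
- Compound 2 `O=C(NCCCCc1ccccc1)n1cc(-c2ccccn2)oc1=O`: < 1000 nM, a limit
- Compound 3 `O=C(NCCCCc1ccccc1)n1cc(-c2cccnc2)oc1=O`: < 1000 nM, a limit

Compound 3 has no number on this read-out, only the limit < 1000 nM. Among the measured compounds shown here, compound 1 and compound 2 are in the same position, and the whole series so far comes down to the limit of < 1000 nM in this assay, at which 3 of the 3 values shown sit.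

Compound 4 `O=C(NCCCCc1ccccc1)n1cc(-c2ccncc2)oc1=O` has the same atoms as compound 3, joined differently, with pyridin-4-yl in place of pyridin-3-yl on an aromatic carbon, next to the ring oxygen (pyridin-4-yl in place of pyridin-3-yl on an aromatic carbon). For the measured compounds named here, three measured steps bear on this change, as each alters the aromatic group at this same place. They are a step that the two limits leave unreadable from compound 1 to compound 2, a step that the two limits leave unreadable from compound 1 to compound 3 and a step that the two limits leave unreadable from compound 2 to compound 3. None of them has a size that can be read, so they offer no measured effect to carry over.

No step beyond the usual scatter is therefore expected in this assay, and no direction can be assigned. The closest guide is a step that the two limits leave unreadable from compound 2 to compound 3, which is the other exchange between pyridinyl groups. The expected step is a step that the limit leaves unreadable from compound 3 to compound 4. The assay may well report only a limit again. For compound 4 the estimated value is 800 nM, with an expected range from 300 nM to 3000 nM.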

Compound 4, solubility: < 1000 nM
Compound 4: a limit, no number; the forecaster's own chance of this, stated with the estimate: 75%; the middle value lies beyond the limit too.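

In this assay compound 4 gives < 1000 nM as a limit, not a number. Among the compounds shown here, its steps from compound 1, compound 2 and compound 3 cannot be read, so no new step emerges. The series still rests on one limit: the limit of < 1000 nM in this assay, at which 4 of the 4 values shown sit. The compounds shown leave open where their actual values lie and whether exchanging the aromatic group changes the result in this assay at all.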